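Benzamide acids at the bile acid receptor: a propoxy-to-benzyloxy step

The source may report more compounds than this note shows. Statements on the series, on what has been measured and on what is new or still open speak of the compounds shown alone.

Compound 1 `Cc1ccc(NC(=O)c2cccc(C(=O)O)c2)cc1`: > 10000 nM
Compound 2 `CCCOc1cccc(C(=O)Nc2cccc(C(=O)O)c2)c1`: 2150 nM

Compound 1 reaches only a limit of the assay, namely (the limit of > 10000 nM in this assay, at which 1 of the 2 values shown sits). For the measured compounds named here, compound 2 is the one compound with a measured number in an assay on isolated protein for agonist activity at Bile acid receptor (Homo sapiens), read by TR-FRET, with a stated time of 3 h, in the absence of a further agent (on this read-out lower numbers stand for an effect already at smaller amounts and higher numbers for an effect only at larger amounts of compound), giving 2150 nM. Compound 3 `Cc1ccc(COc2cccc(C(=O)Nc3cccc(C(=O)O)c3)c2)cc1` differs from compound 2 by 4-methylphenyl in place of ethyl on a saturated chain carbon bound to an oxygen on an aromatic ring. Going by the values given here, no measured pair shows this change, so its size is open. Compound 3 is estimated to be somewhat more potent, with a step of a 3.1-fold lower number from compound 2 to compound 3 (0.49 log units; beyond the scatter) beyond the scatter but modest. Compound 3 is expected at 700 nM, within 150 nM to 3000 nM.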

Compound 3, half-maximal effective concentration: 1430 nM
The estimate for compound 3 lay 2.0-fold (0.31 log units) below the measured number; the measured number falls inside the stated range.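

For the compounds shown here, the pair gives the first reading at this place, on a saturated chain carbon bound to an oxygen on an aromatic ring. In this assay, 4-methylphenyl in place of ethyl gives a 1.5-fold lower number from compound 2 to compound 3 (0.18 log units; within the scatter), so the added six-membered aromatic ring leaves the potency indistinguishable. The compounds shown offer no explanation for this result.

From the compounds shown here alone, how an unsubstituted benzyl, or a longer chain such as butyl, would read at this place stays open. So does the effect of replacing the methyl of the 4-methylbenzyl group with a chlorine or an amine.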